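A few compounds are considered here, and "the series" means these few. Any claim that something is new, unique, unknown or untested is made for them only; others in the source may bear on it.

Compound 1, whose structure is `CN1CCCC(n2cc(S(=O)(=O)c3cccc(F)c3)c3cccnc32)C1`, belongs to a small set of sulfones built on a shared core carrying a ring amine. Among the compounds with values here, in a functional assay on HeLa cells for agonist activity at 5-hydroxytryptamine receptor 6 (Homo sapiens), read by cAMP accumulation and immunoassay (a lower number here means a smaller maximal response, a higher number a larger maximal response), compound 1 gives 75%, the higher of the two numbers measured, though the gap to its only neighbour lies within the scatter. Within the data shown here, that neighbour, compound 2, has the structure `CC(C)N1CCCC(n2cc(S(=O)(=O)c3cccc(F)c3)c3cccnc32)C1` and gives 67% in this assay; the single measured step, isopropyl in place of methyl on an amine nitrogen in a ring, is a number 8 percentage points lower from compound 1 to compound 2 (within the scatter).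

Compound 3, with the structure `CN1CCCC(n2cc(S(=O)(=O)c3cc(Cl)cc(Cl)c3)c3cccnc32)C1`, has not yet been measured. It differs from compound 1 as follows: 3,5-dichlorophenyl in place of 3-fluorophenyl on a sulfonyl sulfur. Among the measured compounds shown here, no measured step touches the ring on the sulfonyl sulfur, so the only step available, at the amine nitrogen, offers no guidance here, and the one step seen was within the scatter.

On that basis the step from compound 1 to compound 3 is expected to be a number 3 percentage points lower from compound 1 to compound 3 (within the scatter). For compound 3 the estimate in this assay is 72%, in the range from 50% to 92%.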

Compound 3, largest response reached (Emax), in percent of the reference or control that the assay uses: 56%
Estimate against measurement, compound 3: 16 percentage points above; low and high end bracket the measured number.
By their numbers in this assay, from the lowest: compound 3; then compounds 2 and 1 (each within the scatter of the next).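

The ring on the sulfonyl sulfur turns out to be a place where a change can shift the maximal response: in this assay, 3,5-dichlorophenyl in place of 3-fluorophenyl gives a number 19 percentage points lower from compound 1 to compound 3 (beyond the scatter), whereas the earlier change on the ring amine nitrogen gave a number 8 percentage points lower from compound 1 to compound 2 (within the scatter). The response is lowered but not lost, as compound 3 still reaches 56%, so this ring tolerates a larger halogen pattern while giving a smaller maximal response. Within the data shown here, the swap alters both the kind and the number of halogens at once, so the single step cannot separate the two, and nothing measured here explains the drop.

As far as these compounds go, it remains open whether a phenyl ring bearing one chlorine would behave like compound 1 or like compound 3, and whether a plain unsubstituted phenyl or a methoxy-bearing phenyl would raise or lower the response further. Also open, from the compounds shown here alone, is whether isopropyl on the amine nitrogen and 3,5-dichlorophenyl on the sulfonyl sulfur would act independently when carried by the same molecule.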